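This account rests on a few compounds, and the source may have more. Where it says the series, first, only, none or still open, it means among the compounds named here.

Two compounds have been measured in a functional assay on CHO cells for agonist activity at Free fatty acid receptor 1 (Homo sapiens), read by a luciferase reporter; a higher number here means a larger maximal response, a lower number a smaller maximal response:
compound 1, `Cc1nc(-c2ccc(C(F)(F)F)cc2)sc1CNc1ccc(CCC(N)=O)cc1`, 88%
compound 2, `Cc1nc(-c2ccc(C(F)(F)F)cc2)sc1CNc1ccc([C@H]2C[C@@H]2C(N)=O)cc1`, 80%

Among the measured compounds shown here, compound 2 stands as the second of two numbers in this assay, and the only step measured so far, a number 8 percentage points lower from compound 1 to compound 2 (within the scatter), leaves compound 2 within the scatter of compound 1. That step concerns the link between the aromatic carbon and the carboxamide; it does not touch the amide nitrogen.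

Compound 3, `Cc1nc(-c2ccc(C(F)(F)F)cc2)sc1CNc1ccc([C@H]2C[C@@H]2C(=O)NC2CCNC2)cc1`, has not yet been measured. It differs from compound 2 by pyrrolidin-3-yl in place of hydrogen on an amide-type nitrogen. For the measured compounds named here, no measured step changes a substituent on the amide nitrogen, so the data give no guide to how this change moves the maximal response in this assay; the single measured step has no direct bearing on it. Compound 2 at 80% and compound 1 at 88% both sit near the top of the scale. For compound 3 the expected step is a number 5 percentage points lower from compound 2 to compound 3 (within the scatter), not beyond the scatter, with a wide range in either direction. Compound 3 is therefore estimated at 75%, between 45% and 100%.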

Compound 3, largest response reached (reported as percent of maximum), in percent of the reference or control that the assay uses: 52%
Compound 3: the middle estimate sits 23 percentage points above what was measured; the measured number falls inside the stated range.
By their numbers in this assay, from the lowest: compound 3; then compounds 2 and 1 (each within the scatter of the next).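

In this assay, the amide nitrogen proves to be a place where a change can move the maximal response: pyrrolidin-3-yl in place of hydrogen gives a number 28 percentage points lower from compound 2 to compound 3 (beyond the scatter), whereas the earlier change to the link to the carboxamide gave only a number 8 percentage points lower from compound 1 to compound 2 (within the scatter). Taken as a whole, 2-((pyrrolidin-3-yl)carbamoyl)cyclopropyl in place of 2-carbamoylethyl gives a number 36 percentage points lower from compound 1 to compound 3 (beyond the scatter), and the two smaller steps place most of that fall at the amide nitrogen rather than at the cyclopropyl link. No measurement given here accounts for the lower response at this nitrogen.

The compounds shown do not tell whether the fall belongs to the ring nitrogen of the pyrrolidin-3-yl group or to the ring as a whole, which a cyclopentyl group or an open-chain 2-aminoethyl group on the same amide nitrogen could separate. They also leave open whether a smaller methyl group there would keep the response of compound 2, and whether pyrrolidin-3-yl on the amide nitrogen of compound 1 would lower the response as far.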